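A few compounds are considered here, and "the series" means these few. Any claim that something is new, unique, unknown or untested is made for them only; others in the source may bear on it.

Series notes. The shared core carries an acrylamide-bearing phenyl on one side and an anilino group whose carbonyl substituent is varied. Compound 1 `C=CC(=O)Nc1ccc(-c2nc(Cl)cc(Nc3ccc(C(=O)N(CC)CC)cc3)n2)cc1` carries a diethylamide at that carbonyl; in a functional assay on Ramos cells (Homo sapiens) for antiproliferative activity, read by MTT assay, with a stated time of 48 h (on this read-out higher numbers stand for weaker inhibition and lower numbers for stronger inhibition), compound 1 gives 11200 nM. Compound 2 `C=CC(=O)Nc1ccc(-c2nc(Cl)cc(Nc3ccc(C(=O)Nc4ccc(OC)cc4)cc3)n2)cc1` carries instead a (4-methoxyphenyl)carbamoyl group; in this assay compound 2 stands as "not determined" (no result reported), so no single number anchors it and it cannot be placed against compound 1. Compound 3 `C=CC(=O)Nc1ccc(-c2nc(Cl)cc(Nc3ccc(C(=O)Nc4cccc(C)c4)cc3)n2)cc1` differs from compound 2 by 3-methylphenyl in place of 4-methoxyphenyl on an amide-type nitrogen. Within the data shown here, no measured pair shows what this exchange does, and the only number available for the whole series is that of compound 1, so the step from compound 2 to compound 3 in this assay is expected to be small and of no settled direction, likely within the scatter. On that basis compound 3 is estimated to give about 6000 nM in this assay, with a range from 1000 nM to 35000 nM, and a real chance that only a limit is reported.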

Compound 3, half-maximal inhibitory concentration: 5390 nM
The estimate for compound 3 lay 1.1-fold (0.05 log units) above the measured number; the measured number falls inside the stated range.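

In this assay the carbonyl substituent now shows a modest effect beyond the scatter, with a 2.1-fold lower number from compound 1 to compound 3 (0.32 log units; beyond the scatter) as (3-methylphenyl)amino takes the place of diethylamino on the carbonyl carbon. Compound 2 has no reported result, so the step to compound 3 cannot be read, and the exchange of 4-methoxyphenyl for 3-methylphenyl remains unplaced. No supporting data are available to explain the step between compound 1 and compound 3.

The compounds shown leave open whether the lower number goes with the aromatic ring or with the amide hydrogen, which compound 3 has and compound 1 lacks. Also open, from the compounds shown here alone, is how a simple methylamino group, a benzylamino group or a morpholine amide at this carbonyl would compare with compound 3.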